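The source may hold more compounds than are shown below. What is called first, only, known or untested is meant among the compounds shown, and "the series" means these compounds.

Compound 1, `Fc1ccccc1N1CCN(Cn2nc(-c3ccc4c(c3)OCCO4)oc2=S)CC1`: in a functional assay on HepG2 cells (Homo sapiens) for antiproliferative activity, read by MTT assay, with a stated time of 48 h (a lower number here means a stronger inhibitor, a higher number a weaker inhibitor), compound 1 gives > 50000 nM, which is a limit of the assay.
Compound 2, `S=c1oc(-c2ccc3c(c2)OCCO3)nn1CN1CCN(c2ccccc2)CC1`: in this assay compound 2 gives > 50000 nM, also a limit.
Compound 3, `COc1ccccc1N1CCN(Cn2nc(-c3ccc4c(c3)OCCO4)oc2=S)CC1`: in this assay compound 3 gives 15500 nM.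

For the measured compounds named here, compound 3 is thus the only one with a number; the other two sit at a limit (the limit of > 50000 nM in this assay, at which 2 of the 3 values shown sit). Compound 4, `S=c1oc(-c2ccc3c(c2)OCCO3)nn1CN1CCN(c2ccccn2)CC1`, differs from compound 3 by pyridin-2-yl in place of 2-methoxyphenyl on an amine nitrogen in a ring. The methoxy is what set compound 3 apart: an at least 3.2-fold lower number from compound 1 to compound 3 (0.50 log units; beyond the scatter) and an at least 3.2-fold lower number from compound 2 to compound 3 (0.50 log units; beyond the scatter). Compound 4 loses that methoxy, so a higher number is expected for compound 4, estimated at 40000 nM (range 12000 nM to 150000 nM), a step of a 2.6-fold higher number from compound 3 to compound 4 (0.41 log units; beyond the scatter).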

Compound 4, half-maximal inhibitory concentration: 11400 nM
The estimate for compound 4 lay 3.5-fold (0.55 log units) above the measured number; the whole stated range lies above it.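

A methoxy group is not needed for a measurable value at this position: with pyridin-2-yl on the amine nitrogen in the ring, compound 4 cannot be told apart from compound 3 in this assay (a 1.4-fold lower number from compound 3 to compound 4 (0.13 log units; within the scatter)). Pyridin-2-yl also does better than phenyl (an at least 4.3-fold lower number from compound 2 to compound 4 (0.64 log units; beyond the scatter)) and 2-fluorophenyl (an at least 4.3-fold lower number from compound 1 to compound 4 (0.64 log units; beyond the scatter)). Both of these steps are only minimum sizes, as compound 1 and compound 2 each give a limit: (the limit of > 50000 nM in this assay, at which 2 of the 4 values shown sit). The compounds shown leave open whether pyridin-3-yl or pyrimidin-2-yl at this position would give a lower number.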